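Removing the Ring Nitrogen's Phenyl in a Pyrazoline Series

The source may report more compounds than this note shows. Statements on the series, on what has been measured and on what is new or still open speak of the compounds shown alone.

Measured so far:
- compound 1, `COc1ccc(/C=C/C(=N\Nc2ccccc2)c2ccccc2)cc1`: 1700 nM
- compound 2, `Clc1ccc(C2CC(c3ccccc3)=NN2c2ccccc2)cc1`: 1170 nM
- compound 3, `Cc1ccc(C2CC(c3ccccc3)=NN2c2ccccc2)cc1`: 4180 nM

In an assay for inhibition of cathepsin H (Capra hircus), using Lineweaver-Burk analysis (a higher number here means a weaker inhibitor, a lower number a stronger inhibitor), compound 3 gives the highest number of the three. For the measured compounds named here, its nearest neighbour is compound 1, and the one measured step, a 3.6-fold higher number from compound 2 to compound 3 (0.55 log units; beyond the scatter), is a change on the aromatic carbon, not on the ring nitrogen. Compound 4, `Cc1ccc(C2CC(c3ccccc3)=NN2)cc1`, differs from compound 3 by hydrogen in place of phenyl on an amine nitrogen in a ring. Going by the values given here, no measured step touches this position, so the direction is open. Without such a step, a change within the scatter is expected, a 1.2-fold higher number from compound 3 to compound 4 (0.08 log units; within the scatter). Compound 4 is therefore expected near 5000 nM, within 1500 nM to 16000 nM.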

Compound 4, inhibition constant: 8200 nM
Beside the measured number, compound 4's estimate is 1.6-fold (0.21 log units) below it; the measured number falls inside the stated range.
By their numbers in this assay, from the lowest: compounds 2 and 1 (each within the scatter of the next); then compounds 3 and 4 (each within the scatter of the next).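

In this assay, for the compounds shown here, the step at this ring nitrogen (a 2.0-fold higher number from compound 3 to compound 4 (0.29 log units; within the scatter)) is the first measured there, and it stays within the usual scatter. Replacing the phenyl, with its 6 heavy atoms and its aromatic ring, by hydrogen therefore gives no reading that separates compound 3 from compound 4. No supporting data bear on this result.

Still open, going by these compounds, is how a methyl, a benzyl or an acetyl group on this nitrogen would read. Also open, on these data alone, is whether hydrogen here would read the same way with the chloro group of compound 2 in place of the methyl.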